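The source may report more compounds than this note shows. Statements on the series, on what has been measured and on what is new or still open speak of the compounds shown alone.

Compound 2 `CC(=O)NCc1cccc([C@]23CCC(N(CCN(C(C)C)C(C)C)C(=O)Nc4ccc(F)c(Cl)c4)CC2C3)c1` was tested in a functional assay for antagonist activity at melanin-concentrating hormone receptor 1 (Homo sapiens) (on this read-out lower numbers stand for stronger inhibition and higher numbers for weaker inhibition), where compound 2 gives 31 nM. Going by the values given here, its only measured neighbour is compound 1 `CC(C)N(CCN(C(=O)Nc1ccc(F)c(Cl)c1)C1CC[C@]2(c3cccc(CNS(C)(=O)=O)c3)CC2C1)C(C)C`, which in this assay gives 18 nM; the step of a 1.7-fold higher number from compound 1 to compound 2 (0.24 log units; within the scatter) lies within the usual scatter, so the two cannot be told apart on these numbers.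

Compound 3 `CCN(CC)Cc1cccc([C@]23CCC(N(CCN(C(C)C)C(C)C)C(=O)Nc4ccc(F)c(Cl)c4)CC2C3)c1` differs from compound 2 by one change: diethylamino in place of acetamido on a saturated chain carbon bound to an aromatic carbon. Among the compounds with values here, only one measured step bears on this, the exchange of acetyl for methylsulfonyl at the same amine nitrogen, a 1.7-fold higher number from compound 1 to compound 2 (0.24 log units; within the scatter), which left the number essentially unchanged. That step keeps the amide-type link, whereas the change to compound 3 removes the carbonyl and its hydrogen-bond donor, so it reaches beyond what has been measured. Within the data shown here, with only that small step as a guide, the expected step of a 1.1-fold higher number from compound 2 to compound 3 (0.05 log units; within the scatter) is none beyond the scatter, though with wide uncertainty. Compound 3 is therefore estimated at 35 nM, with a range from 9 nM to 140 nM.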

Compound 3, inhibition constant: 46 nM
Estimate against measurement, compound 3: 1.3-fold (0.12 log units) below; the measured number falls inside the stated range.
By their numbers in this assay, from the lowest: compounds 1, 2 and 3 (each within the scatter of the next, the first and the last beyond it).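

At this place, on a saturated chain carbon bound to an aromatic carbon, acetamido can be replaced by diethylamino, which has no carbonyl and no hydrogen-bond donor, and this assay shows a 1.5-fold higher number from compound 2 to compound 3 (0.17 log units; within the scatter). Going by these compounds alone, the same exchange made against methanesulfonamido gives a 2.6-fold higher number from compound 1 to compound 3 (0.41 log units; beyond the scatter), the only step in this set beyond the scatter, and a modest one. The group here can thus change from a neutral-looking amide type to a tertiary amine with only a small shift in the number, but no measurement at hand explains these steps.

Still open, as far as these compounds go, is how a smaller amine such as dimethylamino, or a ring amine such as morpholine, would read at this place. A carboxylic acid or a longer chain between the aromatic ring and the amine would test how far this tolerance extends.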